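Replacing the cyanophenyl arm with a short amino-hydroxy chain

This account rests on a few compounds, and the source may have more. Where it says the series, first, only, none or still open, it means among the compounds named here.

Three compounds share one core and differ only in the group on a saturated chain carbon bound to an aromatic nitrogen. Compound 1 `CN(C)CCCn1c(=O)n(C2OC(CO)[C@@H](O)[C@H]2O)c2nc(N)nc(O)c21` carries a 2-(dimethylamino)ethyl group there; in a functional assay (B cells) with Mus musculus as the target (on this read-out lower numbers stand for an effect already at smaller amounts and higher numbers for an effect only at larger amounts of compound), compound 1 gives 194 uM. Compound 2 `Nc1nc(O)c2c(n1)n(C1OC(CO)[C@@H](O)[C@H]1O)c(=O)n2Cc1ccc(Cl)cc1` carries a 4-chlorophenyl group and gives 14 uM, and compound 3 `N#Cc1cccc(Cn2c(=O)n(C3OC(CO)[C@@H](O)[C@H]3O)c3nc(N)nc(O)c32)c1` carries a 3-cyanophenyl group and gives 3 uM. Compound 3 stands lowest of the three, with a 4.7-fold lower number from compound 2 to compound 3 (0.67 log units; beyond the scatter) and a 65-fold lower number from compound 1 to compound 3 (1.81 log units; beyond the scatter).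

Compound 4 `NCC(O)Cn1c(=O)n(C2OC(CO)[C@@H](O)[C@H]2O)c2nc(N)nc(O)c21` is the next step from compound 3. The change is 2-amino-1-hydroxyethyl in place of 3-cyanophenyl on a saturated chain carbon bound to an aromatic nitrogen.

Among the compounds with values here, no measured step shows exactly this change. The closest guide is compound 1, whose group is also a chain rather than a ring: the swap to a ring gave a 14-fold lower number from compound 1 to compound 2 (1.14 log units; beyond the scatter) and a 65-fold lower number from compound 1 to compound 3 (1.81 log units; beyond the scatter). Going the other way, from a ring back to a chain, a large step toward higher numbers is therefore expected, roughly undoing the gain seen from compound 1 to compound 3, so that a 50-fold higher number from compound 3 to compound 4 (1.70 log units; beyond the scatter) is expected. Compound 4 is estimated to give about 150 uM, with a likely range from 30 uM to 600 uM.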

Compound 4, concentration for half-maximal effect: 28 uM
For compound 4 the middle estimate is 5.4-fold (0.73 log units) above the measured one; measured number outside the range, below it.
By their numbers in this assay, from the lowest: compound 3; then compounds 2 and 4 (each within the scatter of the next); then compound 1.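

In this assay, a ring on this position is not required for a number in the low range: the 2-amino-1-hydroxyethyl chain of compound 4 cannot be told apart from the 4-chlorophenyl group of compound 2 (a 2.0-fold higher number from compound 2 to compound 4 (0.30 log units; within the scatter)), although it still falls short of 3-cyanophenyl (a 9.3-fold higher number from compound 3 to compound 4 (0.97 log units; beyond the scatter)). The step between the two chain compounds, (a 6.9-fold lower number from compound 1 to compound 4 (0.84 log units; beyond the scatter)), shows that the swap between chain and ring does not settle the read-out on its own, since what the chain carries also matters. No measurement shown here accounts for any of these differences.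

Compound 4 differs from compound 1 in both its amine and its hydroxyl group, so the compounds shown cannot say which of the two features goes with the lower number. A 2-hydroxyethyl chain without the amine, a 2-aminoethyl chain without the hydroxyl, or a 3-aminophenyl ring would help separate these features and show whether an amine and the 3-cyanophenyl ring can work together at this position.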